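Methoxy for methyl on a second fluorobenzyl core

The source may report more compounds than this note shows. Statements on the series, on what has been measured and on what is new or still open speak of the compounds shown alone.

Of the compounds shown here, three have been measured in a functional assay on RS4-11 cells (Homo sapiens) for inhibition, read by CCK-8 assay, with a stated time of 48 h, tested at 20 uM; a higher number here means more inhibition of growth at the concentration tested, a lower number less inhibition of growth. Compound 1 `Cc1ccc(S(=O)(=O)Oc2ccccc2/C=C(\C#N)C(=O)Nc2nnc(Cc3ccc(F)cc3)s2)cc1` gives 72%, compound 2 `COc1ccc(S(=O)(=O)Oc2ccccc2/C=C(\C#N)C(=O)Nc2nnc(Cc3ccc(F)cc3)s2)cc1` gives 76%, and compound 3 `Cc1ccc(S(=O)(=O)Oc2ccccc2/C=C(\C#N)C(=O)Nc2nnc(Cc3cccc(F)c3)s2)cc1` gives 56%. Compound 1 and compound 2 differ by methoxy in place of methyl on an aromatic carbon, and the step of a number 4 percentage points higher from compound 1 to compound 2 (within the scatter). Compound 1 and compound 3 differ by 3-fluorophenyl in place of 4-fluorophenyl on a saturated chain carbon bound to an aromatic carbon, and the step of a number 16 percentage points lower from compound 1 to compound 3 (beyond the scatter).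

Compound 4 `COc1ccc(S(=O)(=O)Oc2ccccc2/C=C(\C#N)C(=O)Nc2nnc(Cc3cccc(F)c3)s2)cc1` has not been measured yet. It differs from compound 3 by methoxy in place of methyl on an aromatic carbon, the same change as between compound 1 and compound 2, made on a core that differs as 3-fluorophenyl in place of 4-fluorophenyl on a saturated chain carbon bound to an aromatic carbon. Because the earlier step of a number 4 percentage points higher from compound 1 to compound 2 (within the scatter) stayed within the usual scatter, the expected step from compound 3 to compound 4 is similarly small, a number 4 percentage points higher from compound 3 to compound 4 (within the scatter). Compound 4 is therefore estimated at 60%, with a likely range from 50% to 70%.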

Compound 4, percent growth inhibition at one concentration: 74%
Estimate against measurement, compound 4: 14 percentage points below, and the stated range ends below it.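

In this assay, methoxy in place of methyl gives a number 18 percentage points higher from compound 3 to compound 4 (beyond the scatter), while 3-fluorophenyl in place of 4-fluorophenyl on the methoxy compounds gives a number 2 percentage points lower from compound 2 to compound 4 (within the scatter). Set beside the step for the same methoxy change on the other core, the new step does not stand apart: the same change on two cores in this assay, a number 4 percentage points higher (within the scatter) from compound 1 to compound 2 and a number 18 percentage points higher (beyond the scatter) from compound 3 to compound 4, 14 percentage points apart, within the scatter of two such steps. This does not show that the methoxy change behaves differently on the two cores, and two pairs of compounds cannot show that it would behave alike on every core in the series.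

The compounds shown leave open what other groups would do in place of the methoxy, such as a chlorine, an amine or a longer ethoxy chain.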